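The source may hold more compounds than are shown below. What is called first, only, known or untested is meant among the compounds shown, and "the series" means these compounds.

Values in a functional assay on HCT-116 cells (Homo sapiens) for antiproliferative activity, read by MTT assay, with a stated time of 48 h; on this read-out lower numbers stand for stronger inhibition and higher numbers for weaker inhibition:
- Compound 1 `COc1ccc(N(C)c2ccnc(Cl)n2)cc1O`: 422 nM
- Compound 2 `COc1ccc(N(C)c2ccnc(Cl)n2)cc1OCC[Se]C#N`: 1220 nM
- Compound 3 `COc1ccc(N(C)c2ccnc(Cl)n2)cc1OCCC[Se]C#N`: not yet measured

Compound 2, at 1220 nM, holds the higher of the two numbers. For the measured compounds named here, the only measured step is a 2.9-fold higher number from compound 1 to compound 2 (0.46 log units; beyond the scatter). The change now under consideration is a group of 4 heavy atoms (2 carbon, 1 nitrogen, 1 selenium; no ring) in place of a group of 3 heavy atoms (1 carbon, 1 nitrogen, 1 selenium; no ring), on a saturated chain carbon, two bonds along the chain from an oxygen on an aromatic ring. Going by the values given here, the measured step added the whole chain, so it bears only loosely on this smaller change, and no measured step varies the chain length. No shift beyond the scatter is therefore expected in this assay, and no direction is favoured with confidence. The expected step is a 1.1-fold lower number from compound 2 to compound 3 (0.04 log units; within the scatter). The estimate for compound 3 is 1100 nM, with an expected range of 450 nM to 2700 nM.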

Compound 3, half-maximal inhibitory concentration: 3920 nM
Compound 3: the middle estimate sits 3.6-fold (0.55 log units) below what was measured; measured number above the stated range.
By their numbers in this assay, from the lowest: compound 1; then compound 2; then compound 3.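

In this assay, the length of this chain is not neutral: the group of 4 heavy atoms in place of the group of 3 heavy atoms gives a 3.2-fold higher number from compound 2 to compound 3 (0.51 log units; beyond the scatter). Placing the full chain on the oxygen instead of a hydrogen atom gives a 9.3-fold higher number from compound 1 to compound 3 (0.97 log units; beyond the scatter), so the number rises at each extension across compound 1, compound 2 and compound 3, with none of the three going against this. No measurement on hand explains this rise. From the compounds shown here alone, whether a longer chain raises the number further remains open. Also open, going by these compounds, is how a chain ending in an amine or a carboxylic acid, without the selenium and nitrile, would compare.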